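Sulfonyl substituent swap on the piperidine carboxamide series

The source may report more compounds than this note shows. Statements on the series, on what has been measured and on what is new or still open speak of the compounds shown alone.

Compound 1 `CCC(CC)S(=O)(=O)c1ccc(S(=O)(=O)N2CCC[C@@H](C(=O)N3CCC(F)(F)CC3)C2)cc1` stands lowest of the three numbers in a functional assay on BXPC-3 cells (Homo sapiens) for inhibition, read by MTT assay, with a stated time of 7 days (a lower number here means a stronger inhibitor, a higher number a weaker inhibitor), giving 40 nM. Compound 2 `CCN(CC)S(=O)(=O)c1ccc(S(=O)(=O)N2CCC[C@@H](C(=O)NC3COC3)C2)cc1` gives 13800 nM and compound 3 `CCN(CC)S(=O)(=O)c1ccc(S(=O)(=O)N2CCC[C@@H](C(=O)N[C@H]3CCOC3)C2)cc1` gives 5270 nM; neither is connected to compound 1 by a single measured step. Within the data shown here, the one measured step, a 2.6-fold lower number from compound 2 to compound 3 (0.42 log units; beyond the scatter), concerns the amide and says nothing about the sulfonyl. Compound 4 `O=C([C@@H]1CCCN(S(=O)(=O)c2ccc(S(=O)(=O)N3CC[C@H](O)C3)cc2)C1)N1CCC(F)(F)CC1` carries the change (3-hydroxypyrrolidin-1-yl in place of pentan-3-yl on a sulfonyl sulfur). Among the measured compounds shown here, no measured step bears on this change, and compounds 2 and 3 show only that their numbers are far higher than that of compound 1. A step of uncertain size in this assay is therefore expected, more likely toward a higher number, estimated as a 6.3-fold higher number from compound 1 to compound 4 (0.80 log units; beyond the scatter). Compound 4 is expected to give 250 nM, in the range 40 nM to 2500 nM.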

Compound 4, half-maximal inhibitory concentration: 580 nM
Beside the measured number, compound 4's estimate is 2.3-fold (0.37 log units) below it; low and high end bracket the measured number.
By their numbers in this assay, from the lowest: compound 1; then compound 4; then compound 3; then compound 2.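

With the rest of the core of compound 1 held fixed, the group on the sulfonyl sulfur clearly matters in this assay: 3-hydroxypyrrolidin-1-yl in place of pentan-3-yl gives a 15-fold higher number from compound 1 to compound 4 (1.16 log units; beyond the scatter). This change brings in a ring, a hydrogen-bond donor and a hydrogen-bond acceptor together, so the step cannot be assigned to any one of these. No supporting data explain the step. Open, from the compounds shown here alone, is where pyrrolidin-1-yl without the hydroxyl, or a plain cyclopentyl, would fall on the sulfonyl sulfur relative to compound 1 and compound 4.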